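A few compounds are considered here, and "the series" means these few. Any claim that something is new, unique, unknown or untested is made for them only; others in the source may bear on it.

Among the measured compounds shown here, compound 1 (`CCc1ccc(-c2cc(C(=O)Nc3ccc(Oc4ccnc(C(=O)NC)c4)cc3)ncn2)cc1`) gives 6350 nM in a functional assay on MCF7 cells (Homo sapiens) for cytotoxicity, read by MTT assay, with a stated time of 72 h (a higher number here means a weaker inhibitor, a lower number a stronger inhibitor), and so holds the only actual number in this small set. Compound 2 (`CNC(=O)c1cc(Oc2ccc(NC(=O)c3cc(-c4ccc(Cl)cc4)ncn3)cc2)ccn1`) gives > 100000 nM as its reading, and that is a limit of the assay, not a number. For the measured compounds named here, with chloro in place of ethyl on an aromatic carbon there is an at least 15-fold higher number from compound 1 to compound 2 (1.19 log units; beyond the scatter) in this assay and this is the only measured step.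

Compound 3 (`CCc1ccc(-c2cc(C(=O)Nc3ccc(Oc4ccnc(C(=O)NC)c4)c(F)c3)ncn2)cc1`) keeps the ethyl group and differs elsewhere: fluoro in place of hydrogen on an aromatic carbon is fluoro in place of hydrogen on an aromatic carbon, ortho to a (2-(methylcarbamoyl)pyridin-4-yl)oxy group. Going by the values given here, no measured step touches that place. The step of an at least 15-fold higher number from compound 1 to compound 2 (1.19 log units; beyond the scatter) bears on it only loosely, as a warning that one small swap can move this set sharply. The main anchor therefore remains compound 1 at 6350 nM and no shift beyond the scatter is expected, though the margin stays wide, more so toward higher numbers. The expected change is a 1.1-fold lower number from compound 1 to compound 3 (0.02 log units; within the scatter) as an estimate only. For compound 3 the estimated half-maximal inhibitory concentration is 6000 nM with 2000 nM to 25000 nM as the expected range.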

Compound 3, half-maximal inhibitory concentration: 7630 nM
For compound 3 the middle estimate is 1.3-fold (0.10 log units) below the measured one, within the range that was stated.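

Fluoro in place of hydrogen on an aromatic carbon, ortho to a (2-(methylcarbamoyl)pyridin-4-yl)oxy group, gives a 1.2-fold higher number from compound 1 to compound 3 (0.08 log units; within the scatter) in this assay, and this is the first reading from this part of the molecule, since the earlier step touched only the group in the ethyl position. At this position, therefore, the fluoro group leaves the reading within the scatter, whereas the swap at the ethyl position gave an at least 15-fold higher number from compound 1 to compound 2 (1.19 log units; beyond the scatter), so the warning from that step does not carry over to this place in the one case shown. Compound 2 holds a limit and not a number, while compound 1 and compound 3 both give actual numbers, so this new step is the only one in the set read between two numbers: the limit of > 100000 nM in this assay, at which 1 of the 3 values shown sits.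

The compounds shown leave open what a methoxy group or an amine would do at the fluoro position, since a single atom there says little about other groups on that carbon. They also leave open whether a propyl chain or a trifluoromethyl group in the ethyl position would keep a measurable number in this assay.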